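The source may hold more compounds than are shown below. What is called first, only, known or untested is meant among the compounds shown, and "the series" means these compounds.

Compound 1 `O=c1[nH]cnc2c1c(-c1cc3ccccc3o1)cn2[C@@H]1O[C@H](CO)[C@@H](O)[C@H]1O`: > 20000 nM (a limit)
Compound 2 `Nc1nc2c(c(-c3ccoc3)cn2[C@@H]2O[C@H](CO)[C@@H](O)[C@H]2O)c(=O)[nH]1`: 10700 nM
Compound 3 `Nc1nc2c(c(-c3ccsc3)cn2[C@@H]2O[C@H](CO)[C@@H](O)[C@H]2O)c(=O)[nH]1`: > 20000 nM (a limit)

In a functional assay on HeLa S3 cells (Homo sapiens) for antiproliferative activity, read by XTT assay, with a stated time of 72 h (a lower number here means a stronger inhibitor, a higher number a weaker inhibitor), compound 3 gives only a limit, > 20000 nM, and no exact number. That places it at the limit of > 20000 nM in this assay, at which 2 of the 3 values shown sit. Compound 4 `Nc1nc2c(c(-c3cc4ccccc4o3)cn2[C@@H]2O[C@H](CO)[C@@H](O)[C@H]2O)c(=O)[nH]1` has not been measured, and its structure differs from that of compound 3 as follows: 1-benzofuran-2-yl in place of thiophen-3-yl on an aromatic carbon. For the measured compounds named here, the one measured step, an at least 1.8-fold higher number from compound 2 to compound 3 (0.27 log units; that floor lies within the scatter), involves a different swap and does not go beyond the scatter. Compound 1 also carries 1-benzofuran-2-yl, and it gives only a limit, > 20000 nM. No clear change is therefore expected. The estimated step is a number no higher from compound 3 to compound 4 (the limit leaves the size open), within the scatter. For compound 4 the expected value is 20000 nM, with an estimated range from 7000 nM to 40000 nM.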

Compound 4, half-maximal inhibitory concentration: > 20000 nM
Compound 4 was reported as a limit; the forecaster's own chance of this, stated with the estimate: 65%; the middle value sits exactly at the limit.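

In this assay, the two-ring 1-benzofuran-2-yl group at this aromatic carbon gives an at least 1.8-fold higher number from compound 2 to compound 4 (0.27 log units; that floor lies within the scatter), so the floor alone does not establish a real loss against furan-3-yl. The steps to compound 4 from compound 3 and from compound 1 cannot be read, with limits at both ends. Thus even with the amino group on the core, the 1-benzofuran-2-yl group yields no exact number, and the set gathers at one value: the limit of > 20000 nM in this assay, at which 3 of the 4 values shown sit.

Only compound 2 has an exact value, so any differences among the compounds at the limit stay hidden. From the compounds shown here alone, whether an aminomethyl or a carboxylic acid group at this carbon would give a lower number remains open.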